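A few compounds are considered here, and "the series" means these few. Any claim that something is new, unique, unknown or untested is made for them only; others in the source may bear on it.

Measured so far in an ADME assay on L6 cells (Rattus norvegicus) for cytotoxicity (on this read-out higher numbers stand for weaker inhibition and lower numbers for stronger inhibition), for the series
- Compound 1 `Oc1ccc(Br)c2c1C=NCC2` gives > 100000 nM as a limit of the assay
- Compound 2 `Oc1ccc(-c2ccc(O)c3ccccc23)c2c1C=NCC2` gives 94200 nM as a number
- Compound 3 `COc1cccc2c(-c3ccc(O)c4c3CCN=C4)ccc(OC(C)C)c12` gives 27000 nM as a number

Of the two true numbers, compound 3 has the lower, and its gap to compound 2 lies beyond the scatter. Next is compound 4 `COc1cccc2c(-c3ccc(O)c4c3CCN=C4)ccc(O)c12` with the change hydrogen in place of isopropyl on an oxygen on an aromatic ring in which isopropoxy goes to hydroxy. Among the measured compounds shown here, no measured step covers this change. The expectation therefore rests only on the two numbers: a small move towards compound 2 at 94200 nM in this assay and not far beyond the scatter. The expected change is a 1.7-fold higher number from compound 3 to compound 4 (0.22 log units; within the scatter) in the direction of a higher number. For compound 4 the estimate is 45000 nM with an expected range from 16000 nM to 100000 nM in this read-out.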

Compound 4, half-maximal inhibitory concentration: 98200 nM
Estimate against measurement, compound 4: 2.2-fold (0.34 log units) below, within the range that was stated.
By their numbers in this assay, from the lowest: compound 3; then compounds 2 and 4 (each within the scatter of the next). At a limit, above all of these: compound 1.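

In this assay, among the compounds shown here, hydrogen in place of isopropyl on an oxygen on an aromatic ring gives the first single-change reading at this position, a 3.6-fold higher number from compound 3 to compound 4 (0.56 log units; beyond the scatter), so here isopropoxy goes with the lower number and hydroxy with the higher. Methoxy in place of hydrogen on an aromatic carbon, read as a 1.0-fold higher number from compound 2 to compound 4 (0.02 log units; within the scatter), stays within the scatter. Compound 1 stands at a limit of the assay: the limit of > 100000 nM in this assay, at which 1 of the 4 values shown sits.

The isopropoxy reading rests on one pair of compounds. As far as these compounds go, whether a longer chain or an amine on this oxygen would give a lower number than compound 3 stays open.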